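Changing the Aromatic Ring at the End of the Chain

The source may hold more compounds than are shown below. What is called first, only, known or untested is meant among the compounds shown, and "the series" means these compounds.

Compound 1: `O[C@@H](c1ccccc1)[C@H]1CO[C@H](c2ccccc2)[C@@H](C/C=C/c2ccccn2)C1`, 33800 nM
Compound 2: `Cc1ccc(/C=C/C[C@H]2C[C@@H]([C@@H](O)c3ccccc3)CO[C@@H]2c2ccccc2)cc1C`, 10000 nM

In a functional assay on HeLa cells (Homo sapiens) for cytotoxicity, read by WST assay, with a stated time of 48 h (on this read-out higher numbers stand for weaker inhibition and lower numbers for stronger inhibition), compound 1 gives 33800 nM, while compound 2 gives 10000 nM. Within the data shown here, compound 2 thus has the lowest of the two numbers, and its only neighbour, compound 1, sits beyond the scatter above it. Among the measured compounds shown here, that gap is the single measured step, a 3.4-fold lower number from compound 1 to compound 2 (0.53 log units; beyond the scatter), produced by putting 3,4-dimethylphenyl in place of pyridin-2-yl on the chain.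

Compound 3 `O[C@@H](c1ccccc1)[C@H]1CO[C@H](c2ccccc2)[C@@H](C/C=C/c2cccnc2)C1` is the next structure. It differs from compound 2 as follows: pyridin-3-yl in place of 3,4-dimethylphenyl on a double-bonded chain carbon bound to a double-bonded chain carbon. For the measured compounds named here, this largely undoes the one measured step, returning a nitrogen-containing ring to the chain, though now pyridin-3-yl rather than pyridin-2-yl. Because a 3.4-fold lower number from compound 1 to compound 2 (0.53 log units; beyond the scatter) was modest but beyond the scatter, the number for compound 3 is expected to climb back toward compound 1. Compound 3 is therefore expected to give about 25000 nM, within 8000 nM to 70000 nM, a step of a 2.5-fold higher number from compound 2 to compound 3 (0.40 log units; beyond the scatter).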

Compound 3, half-maximal inhibitory concentration: > 100000 nM
Compound 3 ended at the assay's limit (the forecaster's own chance of this, stated with the estimate: 10%); middle value at least 4.0-fold (0.60 log units) from the limit.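

Among these compounds, putting pyridin-3-yl in place of 3,4-dimethylphenyl gives an at least 10-fold higher number from compound 2 to compound 3 (1.00 log units; beyond the scatter) in this assay, a larger step than the only one seen before, so this place on the chain matters more than the earlier compounds suggested. The two pyridine rings are also not interchangeable here, as going from pyridin-2-yl to pyridin-3-yl gives an at least 2.9-fold higher number from compound 1 to compound 3 (0.47 log units; beyond the scatter). Compound 3 gives > 100000 nM, which is a limit of the assay and not a number, so the true size of both steps stays unknown: the limit of > 100000 nM in this assay, at which 1 of the 3 values shown sits.

On these data alone, what remains open is whether the lower number of compound 2 comes from its all-carbon ring or from its two methyl groups. A plain phenyl ring at this place would separate those two readings, and a pyridin-4-yl ring would show whether the pyridine series continues to differ.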